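A few compounds are considered here, and "the series" means these few. Any claim that something is new, unique, unknown or untested is made for them only; others in the source may bear on it.

Compound 1 `CCC[C@@H](CO)Nc1nc(N)nc2cccnc12`: 430 nM
Compound 2 `CCCC[C@H](CO)Nc1nc(N)nc2cccnc12`: 790 nM
Compound 3 `CCCC[C@H](CCO)Nc1nc(N)nc2cccnc12`: 4300 nM

These three compounds share one core and differ only in the side chain attached to the ring nitrogen. In an assay on tissue (PBMC cells) for agonist activity at Toll-like receptor 8 (Homo sapiens), with a stated time of 24 h (on this read-out lower numbers stand for an effect already at smaller amounts and higher numbers for an effect only at larger amounts of compound), compound 3 gives 4300 nM, the highest number of the three; the nearest is compound 2 and the furthest is compound 1. For the measured compounds named here, the only single-point step among the measured compounds is a 5.4-fold higher number from compound 2 to compound 3 (0.74 log units; beyond the scatter), and it is the one that bears on the next change.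

Compound 4 `CCCC[C@H](CN)Nc1nc(N)nc2cccnc12` has not yet been measured. It differs from compound 3 by amino in place of hydroxymethyl on a saturated chain carbon, two bonds along the chain from a nitrogen on an aromatic ring. In effect this reverses the chain extension seen in the step from compound 2 to compound 3 while swapping the oxygen for a nitrogen: compound 4 carries a one-atom side group in the same place where compound 2 carries hydroxy. Going by the values given here, the step from compound 2 to compound 3 suggests that pulling the group back in could recover part of that loss, but no measured compound shows what an amino group does in this position, so the swap itself is untested. A moderate fall in the number is therefore expected, a 3.6-fold lower number from compound 3 to compound 4 (0.55 log units; beyond the scatter), with wide uncertainty. For compound 4 the estimate is 1200 nM, within a range of 300 nM to 5000 nM.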

Compound 4, half-maximal effective concentration: 25000 nM
Compound 4: the middle estimate sits 21-fold (1.32 log units) below what was measured; measured number outside the range, above it.
By their numbers in this assay, from the lowest: compounds 1 and 2 (each within the scatter of the next); then compound 3; then compound 4.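

In this assay the amino group does not stand in for the hydroxy group at this place, on a saturated chain carbon, two bonds along the chain from a nitrogen on an aromatic ring: the swap gives a 32-fold higher number from compound 2 to compound 4 (1.50 log units; beyond the scatter) and is the largest step seen so far. Replacing hydroxymethyl with the smaller amino group also fails to win back what the longer group lost, bringing instead a 5.8-fold higher number from compound 3 to compound 4 (0.76 log units; beyond the scatter) in this series, so making the group smaller does not by itself lower the number, and the kind of group here matters as well as its length. Nothing available explains why amino fares so poorly here.

Going by these compounds, whether a methoxy group or an acetamide in the same place would stay close to compound 2 or climb towards compound 4 remains open. On these data alone, it is also open whether amino in place of hydroxy would have a similar effect on the shorter chain of compound 1.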